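The compounds below may be only part of what the source reports. "The series", "measured", "known", "first", "only" and "open" are said of these compounds alone.

Three compounds share one core and have each been tested in a functional assay on cells for agonist activity at Free fatty acid receptor 1 (Homo sapiens), read by FLIPR and calcium flux; a lower number here means that less compound is needed, a higher number that more compound is needed for the effect. Compound 1 `CC#C[C@@H](Cc1nnn[nH]1)c1ccc(OCc2ccc3scc(-c4cccnc4C)c3c2)cc1` gives 88 nM. Compound 2 `CC#C[C@@H](Cc1nnn[nH]1)c1ccc(OCc2cc(Cl)c3scc(-c4ccccc4C)c3c2)cc1` gives 63 nM. Compound 3 `CC#C[C@@H](Cc1nnn[nH]1)c1ccc(OCc2ccc3sc(C)c(-c4ccc(OCCOC)cc4C)c3c2)cc1` gives 47 nM. Compound 3 thus shows the lowest of the three numbers, but its gap to compound 2 and its gap to compound 1 both lie within the usual scatter of repeated measurements, so the three cannot be ranked against one another on these data.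

Compound 4 `CC#C[C@@H](Cc1nnn[nH]1)c1ccc(OCc2ccc3sc(F)c(-c4ccc(OCCOC)cc4C)c3c2)cc1` has not yet been measured. It differs from compound 3 in a single place: fluoro in place of methyl on an aromatic carbon. Each of the two groups involved is a single atom attached to the same position of the five-membered ring, so the shape of the molecule barely changes.

Within the data shown here, no pair among the measured compounds differs in just this way, so no measured step points the direction. For so small a change, the number for compound 4 is expected to stay close to that of compound 3; the step of a 1.2-fold higher number from compound 3 to compound 4 (0.07 log units; within the scatter) is expected to be small, not beyond the scatter, with no preferred direction. Compound 4 is therefore estimated at 55 nM, with a range from 25 nM to 120 nM.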

Compound 4, half-maximal effective concentration: 18 nM
The estimate for compound 4 lay 3.1-fold (0.49 log units) above the measured number; the measured number lies below the stated range.
By their numbers in this assay, from the lowest: compound 4; then compounds 3, 2 and 1 (each within the scatter of the next).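

In this assay, putting fluoro in place of methyl on the aromatic carbon next to the ring sulfur gives a 2.6-fold lower number from compound 3 to compound 4 (0.42 log units; beyond the scatter), so this position responds to which single atom it carries, even though one heavy atom simply replaces another. Among these compounds, the earlier compounds could not show this: no two of them differed in just one place, and their numbers stood within the scatter of one another, which makes this the first step in the set that can be read as a real difference. No measurement at hand explains why the fluoro compound needs less compound for the effect.

Going by these compounds, whether a larger group such as nitrile or trifluoromethyl at this same position would give a lower or a higher number remains open, since this single step compares only fluoro and methyl. Among the compounds shown here, it is also open whether fluoro would bring a similar step with a different aryl group on the neighbouring ring atom, such as the one in compound 1 or compound 2, as this step was read only with the 4-(2-methoxyethoxy)-2-methylphenyl group in place.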